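Working notes: 1H-indazol-7-yl in place of 3-methylphenyl

The source may report more compounds than this note shows. Statements on the series, on what has been measured and on what is new or still open speak of the compounds shown alone.

Readings in a physicochemical assay for solubility (a higher number here means a more soluble compound, a lower number a less soluble compound), so far:
- compound 1 `CNC(=O)c1cc(C(=O)NC2CC2)cn(Cc2cccc3[nH]ccc23)c1=O` gives 78 ug/mL
- compound 2 `CNC(=O)c1cc(C(=O)NC2CC2)cn(Cc2cccc([C@@H](C)O)c2)c1=O` gives >= 131 ug/mL (a limit)
- compound 3 `CNC(=O)c1cc(C(=O)NC2CC2)cn(Cc2cccc(C)c2)c1=O` gives >= 205 ug/mL (a limit)

Compound 3 has no numerical reading, only a limit (>= 205 ug/mL) in this assay.

Compound 4 `CNC(=O)c1cc(C(=O)NC2CC2)cn(Cc2cccc3cn[nH]c23)c1=O` is next, with 1H-indazol-7-yl in place of 3-methylphenyl on a saturated chain carbon bound to an aromatic nitrogen.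

Going by the values given here, three measured steps touch this place. Going from 1H-indol-4-yl to 3-methylphenyl gave an at least 2.6-fold higher number from compound 1 to compound 3 (0.41 log units; beyond the scatter) as a result. Going from 1H-indol-4-yl to 3-(1-hydroxyethyl)phenyl gave an at least 1.6-fold higher number from compound 1 to compound 2 (0.22 log units; that floor lies within the scatter) as a result. Methyl in place of 1-hydroxyethyl gave a step that the two limits leave unreadable from compound 2 to compound 3 as a result, so that step offers no guide.

Among the compounds with values here, the first step bears most directly, since 1H-indol-4-yl is the only measured group here with two aromatic rings, like 1H-indazol-7-yl. Run in reverse, it points to a lower number of at least modest size, though it rests on compound 1 alone, at 78 ug/mL in this assay.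

The expected step is an at least 2.5-fold lower number from compound 3 to compound 4 (0.40 log units; beyond the scatter) in this estimate.

For compound 4 the expected value is 80 ug/mL with an estimated range of 30 ug/mL to 200 ug/mL in this assay.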

Compound 4, solubility: >= 181 ug/mL
Compound 4 gave a limit, no number (the forecaster's own chance of this, stated with the estimate: 15%); middle value at least 2.2-fold (0.35 log units) from the limit.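

In this assay compound 4 gives >= 181 ug/mL, which is a limit and not a number. On the saturated chain carbon bound to an aromatic nitrogen, 1H-indazol-7-yl in place of 1H-indol-4-yl gives an at least 2.3-fold higher number from compound 1 to compound 4 (0.36 log units; beyond the scatter), so among the two groups with two aromatic rings shown at this place, only 1H-indol-4-yl has the lower reading, and two aromatic rings there do not by themselves bring that reading. The steps to compound 4 from compound 2 and from compound 3 cannot be read, since each joins two limits, and no order among these three compounds can be stated.

Going by these compounds, with only limits for compound 2, compound 3 and compound 4, it remains open how 1H-indazol-7-yl truly compares with 3-methylphenyl or 3-(1-hydroxyethyl)phenyl in this assay. Also open, on these data alone, is how the reading would respond at this place to a phenyl carrying an amine or a carboxylic acid, and whether the difference between 1H-indazol-7-yl and 1H-indol-4-yl would persist with a 1H-indol-7-yl group.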